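Bromo-to-fluoro swap on the N-aryl ring of compound 2

The compounds below may be only part of what the source reports. "The series", "measured", "known", "first", "only" and "open" are said of these compounds alone.

Two members of the series have been run in a functional assay on Caco-2 cells (Homo sapiens) for antiproliferative activity, read by MTT assay, with a stated time of 72 h; a higher number here means a weaker inhibitor, a lower number a stronger inhibitor. Compound 1 `CS(=O)(=O)c1ccc(-c2nc(SCCCOC(=O)/C=C/c3ccc(O)c(O)c3)nn2-c2ccc(Br)cc2)cc1` gives 12400 nM. Compound 2 `CC(=O)Oc1ccc(/C=C/C(=O)NCCCSc2nc(-c3ccc(S(C)(=O)=O)cc3)n(-c3ccc(Br)cc3)n2)cc1OC(C)=O` gives 26100 nM, the higher of the two numbers, separated from compound 1 by a gap beyond the scatter.

Compound 3 `CC(=O)Oc1ccc(/C=C/C(=O)NCCCSc2nc(-c3ccc(S(C)(=O)=O)cc3)n(-c3ccc(F)cc3)n2)cc1OC(C)=O` has not been measured. It differs from compound 2 in one place: fluoro in place of bromo on an aromatic carbon. Within the data shown here, no measured pair in this set shows this change, so there is nothing to calibrate its effect against. The rest of the molecule, the diacetylated cinnamamide chain and the shared core, is kept as in compound 2.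

Among the measured compounds shown here, with no comparable step on record, the expected step from compound 2 to compound 3 is small, likely within the scatter, and its direction cannot be called from the data. Compound 3 is therefore estimated at 30000 nM in this assay, within a range of 12000 nM to 75000 nM, an expected step of a 1.1-fold higher number from compound 2 to compound 3 (0.06 log units; within the scatter).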

Compound 3, half-maximal inhibitory concentration: 20800 nM
Estimate against measurement, compound 3: 1.4-fold (0.16 log units) above; low and high end bracket the measured number.
By their numbers in this assay, from the lowest: compounds 1, 3 and 2 (each within the scatter of the next, the first and the last beyond it).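

In this assay, among these compounds, the 4-bromophenyl to 4-fluorophenyl exchange gives the first reading of a single change: a 1.3-fold lower number from compound 2 to compound 3 (0.10 log units; within the scatter). With the diacetylated cinnamamide chain and the shared core held constant, bromo and fluoro on this aromatic carbon, para to a large group, cannot be told apart in this assay, although this rests on one pair alone. Nothing available offers an explanation for this reading.

The compounds shown leave open whether hydrogen, methoxy, trifluoromethyl or a dimethylamino group on this same aromatic carbon would also stay within the scatter of compound 2, as both groups seen here are halogens. Also open, as far as these compounds go, is whether fluoro in place of bromo reads the same on the chain of compound 1, which carries an ester and free hydroxyl groups, and, as compound 1 and compound 2 differ in more than one place, how the ester, the amide and the acetyl groups each contribute to the gap between those two compounds.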